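Bromo in place of chloro on the shared core

The source may hold more compounds than are shown below. What is called first, only, known or untested is meant among the compounds shown, and "the series" means these compounds.

In a functional assay on ASPC1 cells (Homo sapiens) for antiproliferative activity, read by sulforhodamine B assay, with a stated time of 48 h (on this read-out higher numbers stand for weaker inhibition and lower numbers for stronger inhibition), compound 1 `CO/N=C1/C(=O)N(CCCCCCC(=O)NO)c2ccc(F)cc21` gives 970 nM and compound 2 `CO/N=C1/C(=O)N(CCCCCCC(=O)NO)c2ccc(Cl)cc21` gives 490 nM, which places compound 2 within the scatter of compound 1. Compound 3 `CO/N=C1/C(=O)N(CCCCCCC(=O)NO)c2ccc(Br)cc21` has bromo in place of chloro on an aromatic carbon. Going by the values given here, the one measured step bearing on this change, chloro in place of fluoro, is a 2.0-fold lower number from compound 1 to compound 2 (0.30 log units; within the scatter) and lies within the scatter. No step beyond the scatter is therefore expected in this assay. The expected step is a 1.2-fold lower number from compound 2 to compound 3 (0.09 log units; within the scatter). Compound 3 is estimated at 400 nM, with an expected range of 170 nM to 950 nM.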

Compound 3, half-maximal inhibitory concentration: 1680 nM
Compound 3: middle estimate off by 4.2-fold (0.62 log units), on the low side, outside the stated range (above it).
By their numbers in this assay, from the lowest: compounds 2, 1 and 3 (each within the scatter of the next, the first and the last beyond it).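

In this assay there is a 3.4-fold higher number from compound 2 to compound 3 (0.54 log units; beyond the scatter), and this is the only step shown that lies beyond the scatter. Bromo in place of fluoro gives a 1.7-fold higher number from compound 1 to compound 3 (0.24 log units; within the scatter), so the three halogens form no steady trend and only compound 2 and compound 3 stand apart. Nothing available explains this step.

From the compounds shown here alone, whether a methoxy group, an amine or a nitrile at this carbon would depart from the halogens remains open. Also open, going by these compounds, is whether the step between chloro and bromo would persist with a longer chain on the shared core.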